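Tert-butyl in place of propanoyl on an aromatic carbon

The source may report more compounds than this note shows. Statements on the series, on what has been measured and on what is new or still open speak of the compounds shown alone.

Compound 1 `Cc1ccn2c(C(=O)NCc3ccc(Cl)cc3)c(C)nc2c1` gives 94.3%
Compound 2 `CCC(=O)c1ccccc1OC(=O)c1coc(-c2ccccc2)n1` gives 1.8%
Compound 3 `Cc1cc(C)c(OC(=O)c2coc(-c3ccccc3)n2)c(C)c1` gives 1.4%

These values come from a physicochemical assay for metabolic stability, read by LC-MS, in simulated gastric fluid, with a stated time of 15 min, tested at 50 uM; on this read-out lower numbers stand for a less stable compound and higher numbers for a more stable compound. Compound 2 lies within the scatter of compound 3 and far beyond the scatter from compound 1. Compound 4 `CC(C)(C)c1ccccc1OC(=O)c1coc(-c2ccccc2)n1` has tert-butyl in place of propanoyl on an aromatic carbon. Among the measured compounds shown here, no measured pair shows this change directly. Compound 2 shares its core with compound 3 but carries different groups, and compound 3 still gives 1.4%, so no change beyond the scatter is expected. The expected size is a number 1.2 percentage points higher from compound 2 to compound 4 (within the scatter). In this assay, the estimate for compound 4 is 3%, with an expected range from 0.5% to 15%.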

Compound 4, percent of the compound remaining: 0.7%
Estimate against measurement, compound 4: 2.3 percentage points above; the measured number falls inside the stated range.
By their numbers in this assay, from the lowest: compounds 4, 3 and 2 (each within the scatter of the next); then compound 1.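

Tert-butyl in place of propanoyl on this aromatic carbon gives a number 1.1 percentage points lower from compound 2 to compound 4 (within the scatter) in this assay. Taking away the carbonyl of propanoyl, and with it the hydrogen-bond acceptor, therefore leaves no change that can be told from the scatter at this position. No measurement here explains why the read-out stays put. Still open, on these data alone, is whether an amine or a carboxylic acid on this same aromatic carbon would give a number that stands apart from compound 2. As far as these compounds go, whether the step holds on a different core also remains unknown.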